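Toward Compound 4: From a Limit to a Number

This account rests on a few compounds, and the source may have more. Where it says the series, first, only, none or still open, it means among the compounds named here.

Compound 1 `O=C1/C(=C\c2c(Cl)cccc2Cl)c2ccccc2N1c1c(Cl)cccc1Cl` was tested in a functional assay on B16-F10 cells (Homo sapiens) for cytotoxicity against B16-F10 (Mus musculus), read by MTT assay, with a stated time of 72 h; on this read-out higher numbers stand for an effect only at larger amounts of compound and lower numbers for an effect already at smaller amounts. For compound 1 the read-out is only a limit of the assay, > 100 ug/mL, so no number is known for it. Its value is the one sitting at the limit of > 100 ug/mL in this assay, at which 1 of the 3 values shown sits. Two relatives carry a different group on the same chain carbon. Compound 2 `O=C1/C(=C\c2cccc(Br)c2)c2ccccc2N1c1c(Cl)cccc1Cl` gives 8 ug/mL in this assay, and compound 3 `O=C1/C(=C\c2ccccc2Cl)c2ccccc2N1c1c(Cl)cccc1Cl` gives 39 ug/mL. Both changes lower the number beyond the scatter: an at least 12-fold lower number from compound 1 to compound 2 (1.09 log units; beyond the scatter) and an at least 2.5-fold lower number from compound 1 to compound 3 (0.40 log units; beyond the scatter). Between the two measured relatives, a 4.9-fold higher number from compound 2 to compound 3 (0.69 log units; beyond the scatter) shows the 3-bromophenyl compound sitting lower than the 2-chlorophenyl one.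

Compound 4 `O=C1/C(=C\c2cccc(Cl)c2)c2ccccc2N1c1c(Cl)cccc1Cl` has not yet been measured. It differs from compound 1 by 3-chlorophenyl in place of 2,6-dichlorophenyl on a double-bonded chain carbon bound to a double-bonded ring carbon. Compound 2 carries 3-bromophenyl where compound 4 carries 3-chlorophenyl, so the step of an at least 12-fold lower number from compound 1 to compound 2 (1.09 log units; beyond the scatter) is the closest guide, while the smaller step to compound 3 is the less relevant comparison. A large drop beyond the scatter is therefore expected. Compound 4 is estimated at 12 ug/mL, with a range from 4 ug/mL to 40 ug/mL. The step this estimate implies is expected to be an at least 8.3-fold lower number from compound 1 to compound 4 (0.92 log units; beyond the scatter).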

Compound 4, concentration for half-maximal effect: 8 ug/mL
Compound 4: the middle estimate sits 1.5-fold (0.18 log units) above what was measured, within the range that was stated.
By their numbers in this assay, from the lowest: compounds 2 and 4 (each within the scatter of the next); then compound 3. At a limit, above all of these: compound 1.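

In this assay, 3-chlorophenyl in place of 2-chlorophenyl gives a 4.9-fold lower number from compound 3 to compound 4 (0.69 log units; beyond the scatter) and is beyond the scatter, so with a single chloro on both compounds, its place on the phenyl ring alone changes the read-out. The earlier compounds shown here could not show this, as compound 2 and compound 3 differ in both the halogen and its place. The halogen itself, by contrast, shows no effect here, with chloro in place of bromo giving no change at the digits printed from compound 2 to compound 4 (within the scatter), while 3-chlorophenyl in place of 2,6-dichlorophenyl gives an at least 12-fold lower number from compound 1 to compound 4 (1.09 log units; beyond the scatter) and that large step starts from a limit of the assay, not a number: the limit of > 100 ug/mL in this assay, at which 1 of the 4 values shown sits.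

The compounds shown leave open whether the chloro of 3-chlorophenyl can give way to a different kind of group, such as an amine, a methoxy group or a carboxylic acid, and still keep the read-out of compound 4. They also leave open what a phenyl ring with no halogen at all would give, and how any change to the rest of the core of compound 4 would read.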